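One core swap, made twice, under mouse liver microsomes

The compounds below may be only part of what the source reports. "The series", "measured", "known", "first", "only" and "open" are said of these compounds alone.

Three amides have been measured in an ADME assay on microsomes from liver (Mus musculus) for metabolic stability, read by LC-MS, with a stated time of 30 min, tested at 1 uM; on this read-out lower numbers stand for a less stable compound and higher numbers for a more stable compound. Compound 1 `O=C(NCc1ccc(S(=O)(=O)c2ccccc2)cc1)c1cc2ccncc2s1` gives 21%. Compound 2 `O=C(NCc1ccc(S(=O)(=O)c2ccccc2)cc1)c1ccc2nccn2c1` gives 18%, and compound 3 `O=C(NCc1ccc(S(=O)(=O)c2cccc(C(F)(F)F)c2)cc1)c1ccc2nccn2c1` gives 17%. All three numbers lie within the scatter of one another, so none of them can be called more or less stable than the rest.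

Compound 2 and compound 1 differ by a group of 9 heavy atoms (7 carbon, 1 nitrogen, 1 sulfur; one five-membered aromatic ring with 1 hetero atom, one six-membered aromatic ring with 1 hetero atom) in place of a group of 9 heavy atoms (7 carbon, 2 nitrogen; one five-membered aromatic ring with 2 hetero atoms, one six-membered aromatic ring with 1 hetero atom), on a carbonyl carbon; the step in this assay is a number 3 percentage points higher from compound 2 to compound 1 (within the scatter). Compound 3 keeps the core of compound 2 and differs from it by trifluoromethyl in place of hydrogen on an aromatic carbon; that step is a number 1 percentage points lower from compound 2 to compound 3 (within the scatter).

Compound 4 `O=C(NCc1ccc(S(=O)(=O)c2cccc(C(F)(F)F)c2)cc1)c1cc2ccncc2s1` has not been measured. Within the data shown here, it differs from compound 3 by a group of 9 heavy atoms (7 carbon, 1 nitrogen, 1 sulfur; one five-membered aromatic ring with 1 hetero atom, one six-membered aromatic ring with 1 hetero atom) in place of a group of 9 heavy atoms (7 carbon, 2 nitrogen; one five-membered aromatic ring with 2 hetero atoms, one six-membered aromatic ring with 1 hetero atom), on a carbonyl carbon, which is the same change as the one from compound 2 to compound 1, at a place worded identically in both cases; the two starting compounds differ only by the trifluoromethyl already described. The expectation for compound 4 rests on the earlier step, which was a number 3 percentage points higher from compound 2 to compound 1 (within the scatter). On that basis the step expected for compound 4 is a number 3 percentage points higher from compound 3 to compound 4 (within the scatter). Compound 4 is therefore estimated at 20% in this assay, within a range from 10% to 32%.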

Compound 4, percent of the compound remaining: 35%
Compound 4: middle estimate off by 15 percentage points, on the low side; the measured number lies above the stated range.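

In this assay, the core change gave a number 18 percentage points higher from compound 3 to compound 4 (beyond the scatter), so the step did not carry over at its earlier size once trifluoromethyl was present: the same change on two cores in this assay, a number 3 percentage points higher (within the scatter) from compound 2 to compound 1 and a number 18 percentage points higher (beyond the scatter) from compound 3 to compound 4, 15 percentage points apart, beyond the scatter of two such steps Read the other way, trifluoromethyl in place of hydrogen gave a number 14 percentage points higher from compound 1 to compound 4 (beyond the scatter) on the core of compound 1, and this step did not carry from one core to the other either: the same change on two cores in this assay, a number 1 percentage points lower (within the scatter) from compound 2 to compound 3 and a number 14 percentage points higher (beyond the scatter) from compound 1 to compound 4, 15 percentage points apart, beyond the scatter of two such steps The two changes therefore do not simply add in these four compounds, but the result rests on a single set of matched pairs and does not show why they fail to add or whether the same would happen on another core.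

The compounds shown leave open whether a chlorine, a methyl or a methoxy group in place of trifluoromethyl would combine with the core of compound 1 in the same way. They also leave open whether an amine or a carboxylic acid on that core would follow compound 4 or compound 1.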